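Aryl for alkyl on the saturated ring carbon

A few compounds are considered here, and "the series" means these few. Any claim that something is new, unique, unknown or untested is made for them only; others in the source may bear on it.

Of the compounds shown here, two have been measured in an assay on Sf9 cells for inhibition of serine/threonine-protein kinase 4 (Homo sapiens), read by luminescence and ADP-Glo, with a stated time of 1 h, in the presence of a further agent that is not named here; a lower number here means a stronger inhibitor, a higher number a weaker inhibitor. Compound 2 `CC(C)CC1C(=O)N(C)c2cnc(Nc3ccc(S(N)(=O)=O)cc3)nc2N1C` gives 77 nM and compound 1 `CN1C(=O)C(C2CC2)N(C)c2nc(Nc3ccc(S(N)(=O)=O)cc3)ncc21` gives 136 nM; the step of a 1.8-fold lower number from compound 1 to compound 2 (0.25 log units; within the scatter) is within the scatter, so the two are not separated. Compound 3 `CN1C(=O)C(c2cccc(Cl)c2)N(C)c2nc(Nc3ccc(S(N)(=O)=O)cc3)ncc21` carries 3-chlorophenyl in place of isobutyl on a saturated ring carbon. Among the compounds with values here, the only measured step at this saturated ring carbon is that one, and it stayed within the scatter, so a step in this assay of no more than the scatter is expected, in either direction. Compound 3 is estimated at 80 nM, range 25 nM to 250 nM, which means an expected step of a 1.0-fold higher number from compound 2 to compound 3 (0.02 log units; within the scatter).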

Compound 3, half-maximal inhibitory concentration: 989 nM
Compound 3: middle estimate off by 12-fold (1.09 log units), on the low side, outside the stated range (above it).
By their numbers in this assay, from the lowest: compounds 2 and 1 (each within the scatter of the next); then compound 3.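

This saturated ring carbon is not indifferent to what it carries: isobutyl and cyclopropyl were not separated, but in this assay 3-chlorophenyl brings a 13-fold higher number from compound 2 to compound 3 (1.11 log units; beyond the scatter) and a 7.3-fold higher number from compound 1 to compound 3 (0.86 log units; beyond the scatter). Of the groups shown, only the one with an aromatic ring stands apart from the others. Nothing at hand bears on the cause of this step. Still open, on these data alone, is whether the ring or its chlorine carries the step, which unsubstituted phenyl would help settle. Also open, as far as these compounds go, is how a benzyl group or an amine would read at this carbon.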